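Shortening the chain of a diyne ester-ether

A few compounds are considered here, and "the series" means these few. Any claim that something is new, unique, unknown or untested is made for them only; others in the source may bear on it.

Measured compounds in a functional assay on SK-MEL-2 cells (Homo sapiens) for cytotoxicity; on this read-out higher numbers stand for an effect only at larger amounts of compound and lower numbers for an effect already at smaller amounts:
- compound 1, `CCCCCCCC#CC#CCO`: 4.45 ug/mL
- compound 2, `C=CCCCCCCCC#CC#CCOCC(=O)OC`: > 30 ug/mL

Compound 1, `CCCCCCCC#CC#CCO`, carries a free hydroxyl on the diyne chain, and in this assay compound 1 gives 4.45 ug/mL. Compound 2, `C=CCCCCCCCC#CC#CCOCC(=O)OC`, has the hydroxyl etherified to the ester side chain and a longer alkyl chain; in this assay compound 2 gives > 30 ug/mL, which is a limit of the assay and not a number. Of the two values shown, one sits at the limit of > 30 ug/mL in this assay, at which 1 of the 2 values shown sits.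

Compound 3, `CCCCCCCC#CC#CCOCC(=O)OC`, is not yet measured. It differs from compound 2 as follows: hydrogen in place of vinyl on a saturated chain carbon, seven bonds along the chain from a triple-bonded carbon. Going by the values given here, no measured pair isolates this change, and compound 2 itself stands only at a limit, so the step can only be guessed. A step from compound 2 to compound 3 of an at least 1.2-fold lower number from compound 2 to compound 3 (0.07 log units; that floor lies within the scatter) is expected, with no clear direction beyond the scatter. Compound 3 is estimated at 25 ug/mL, in a range from 8 ug/mL to 60 ug/mL.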

Compound 3, concentration for half-maximal effect: > 30 ug/mL
Compound 3: only a limit was reported; the forecaster's own chance of this, stated with the estimate: 50%; at least 1.2-fold (0.07 log units) between middle value and limit.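

Compound 3 keeps the chain of compound 1 and changes only the oxygen end, so this pair isolates the change that compounds 1 and 2 left mixed with the chain difference: (methoxycarbonyl)methyl in place of hydrogen on an oxygen on a saturated carbon gives an at least 6.7-fold higher number from compound 1 to compound 3 (0.82 log units; beyond the scatter) in this assay. In this assay compound 3 gives > 30 ug/mL, which is a limit of the assay and not a number. The step for hydrogen in place of vinyl cannot be read, so the chain end shows no effect of its own here: the limit of > 30 ug/mL in this assay, at which 2 of the 3 values shown sit.

On these data alone, whether the loss belongs to the ether link or to the ester remains open; a carboxylic acid or a plain methyl ether on the same oxygen would separate the two. As far as these compounds go, how a vinyl end or a longer chain acts on the free hydroxyl form also remains open.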